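Swapping the Urea for a Hexylamine on a Shared Core

The compounds below may be only part of what the source reports. "The series", "measured", "known", "first", "only" and "open" are said of these compounds alone.

In an assay for inhibition of acyl-CoA:cholesterol acyltransferase (Oryctolagus cuniculus), using microsomes (on this read-out higher numbers stand for weaker inhibition and lower numbers for stronger inhibition), compound 1 `CCCCNC(=O)Nc1c(OCCCn2cnc(-c3ccccc3)c2)cccc1N(C)C` gives 140 nM. Among the three compounds measured so far it holds the second highest number; the nearest to it is compound 3 `CN(C)c1cccc(OCCCn2cnc(-c3ccccc3)c2)c1NC(=O)NC1CCCCC1`, which gives 73 nM, and the furthest is compound 2 `CCCNC(=O)Nc1c(OCCCn2cnc(-c3ccccc3)c2)cccc1N(C)C`, which gives 660 nM. The step from compound 1 to compound 3 reads a 1.9-fold lower number from compound 1 to compound 3 (0.28 log units; within the scatter), whereas a 4.7-fold higher number from compound 1 to compound 2 (0.67 log units; beyond the scatter) and a 9.0-fold lower number from compound 2 to compound 3 (0.96 log units; beyond the scatter) are modest movements that go beyond the scatter.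

Compound 4 `CCCCCCNc1c(OCCCn2cnc(-c3ccccc3)c2)cccc1N(C)C` differs from compound 1 in a single place: hexyl in place of butylcarbamoyl on a nitrogen on an aromatic ring. All three measured steps vary only the group on the amide-type nitrogen and keep the urea intact, so none of them tests what happens when the butylcarbamoyl group itself is removed. They do show that this end of the molecule matters to the number, and the change in compound 4 is larger than any of them, since it takes away both the hydrogen-bond donor and the hydrogen-bond acceptor that the urea carried. A step beyond the scatter towards a higher number is therefore expected, with wide uncertainty. Compound 4 is estimated at 1500 nM, within 300 nM to 8000 nM, which corresponds to an expected step of an 11-fold higher number from compound 1 to compound 4 (1.03 log units; beyond the scatter).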

Compound 4, half-maximal inhibitory concentration: 11000 nM
The estimate for compound 4 lay 7.3-fold (0.87 log units) below the measured number, outside the stated range (above it).
By their numbers in this assay, from the lowest: compounds 3 and 1 (each within the scatter of the next); then compound 2; then compound 4.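

Compared with the urea compounds in this assay, the swap to hexyl gives large steps whichever urea it starts from: (a 79-fold higher number from compound 1 to compound 4 (1.90 log units; beyond the scatter)), (a 150-fold higher number from compound 3 to compound 4 (2.18 log units; beyond the scatter)) and (a 17-fold higher number from compound 2 to compound 4 (1.22 log units; beyond the scatter)). Even the smallest of these exceeds the largest step seen when only the group at the far end of the urea changed (a 9.0-fold lower number from compound 2 to compound 3 (0.96 log units; beyond the scatter)), so on these four compounds the carbamoyl unit on the nitrogen on an aromatic ring matters more to the number than the choice of butyl, propyl or cyclohexyl at its end. No independent measurement here explains why this happens.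

The swap removes the carbonyl and the amide-type nitrogen together while also changing the chain, so the compounds shown cannot say which of these accounts for the jump; a pentanoyl amide or a thiourea on the same nitrogen would begin to pull those parts apart. Also open, going by these compounds, is how a hexyl chain would behave when it sits on the urea itself, as hexylcarbamoyl, which would separate the effect of the chain from that of losing the urea.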